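Diiodosalicyloyl hydrazides: cytotoxicity notes on a small set

The source may hold more compounds than are shown below. What is called first, only, known or untested is meant among the compounds shown, and "the series" means these compounds.

Of the compounds shown here, two in this set have been tested in a functional assay on HepG2 cells (Homo sapiens) for cytotoxicity, with a stated time of 24 h; a lower number here means a stronger inhibitor, a higher number a weaker inhibitor. Compound 1 `Cc1ccc(C(=O)N/N=C/c2cc(I)c(O)c(I)c2)cc1` carries a hydrazone linker; in this assay it reaches only the limit > 100000 nM, which is a limit of the measurement and not a number. Compound 2 `O=C(NNC(=O)c1cc(I)cc(I)c1O)c1ccccc1`, a diacyl hydrazide, gives 98000 nM in this assay. That is the only number shown in the set; the other value is a limit, namely (the limit of > 100000 nM in this assay, at which 1 of the 2 values shown sits), so compound 2 cannot be ranked against compound 1.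

Compound 3 `O=C(NNC(=O)c1cc(I)cc(I)c1O)c1ccc(Br)cc1` differs from compound 2 by bromo in place of hydrogen on an aromatic carbon. Within the data shown here, no measured pair shows this change. The expectation is a step from compound 2 to compound 3 of about a 1.4-fold lower number from compound 2 to compound 3 (0.15 log units; within the scatter), which is not beyond the usual scatter. Compound 3 is therefore estimated at 70000 nM in this assay, with a range from 30000 nM to 150000 nM; a limit rather than a number remains a real possibility.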

Compound 3, half-maximal inhibitory concentration: 62800 nM
For compound 3 the middle estimate is 1.1-fold (0.05 log units) above the measured one; the range from low to high includes it.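

In this assay, among these compounds, phenyl to 4-bromophenyl gives a 1.6-fold lower number from compound 2 to compound 3 (0.19 log units; within the scatter), and this is the first step in the set that can be read between two numbers. At this position, on an aromatic carbon para to a large group, the two values cannot be told apart, so a single bromo establishes no trend for the series. No measured property shown for these compounds bears on this step.

Still open, on these data alone, is whether an amine, a carboxylic acid or a methoxy group in the same place would give a step beyond the scatter. Also open, as far as these compounds go, is how the hydrazone linker of compound 1 and the diacyl hydrazide linker of compound 2 compare when the rest of the structure is the same.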